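Propanoyl on the amino nitrogen of compound 2

The source may hold more compounds than are shown below. What is called first, only, known or untested is meant among the compounds shown, and "the series" means these compounds.

Measured in a functional assay on BaF3 cells (Mus musculus) for inhibition, read by CCK-8 assay, with a stated time of 72 h; on this read-out lower numbers stand for stronger inhibition of growth and higher numbers for weaker inhibition of growth:
Compound 1 `CNc1cc(Oc2ccc(NC(=O)Nc3ccc(C)c(C(F)(F)F)c3)cc2)ncn1`: > 10000 nM
Compound 2 `Cc1ccc(NC(=O)Nc2ccc(Oc3cc(N)ncn3)cc2)cc1C(F)(F)F`: > 10000 nM

Compound 2 gives only a limit, > 10000 nM, not a number. Both compounds stand at the limit of > 10000 nM in this assay, at which 2 of the 2 values shown sit.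

Compound 3 `CCC(=O)Nc1cc(Oc2ccc(NC(=O)Nc3ccc(C)c(C(F)(F)F)c3)cc2)ncn1` differs from compound 2 by propanoyl in place of hydrogen on a nitrogen on an aromatic ring. Among the compounds with values here, the one measured step is a step that the two limits leave unreadable from compound 1 to compound 2, so it offers no size to carry over, and no step of known size or direction is expected in this assay. A value near the limit is expected. The expected step is an at least 1.2-fold lower number from compound 2 to compound 3 (0.09 log units; that floor lies within the scatter). The estimate for compound 3 is 8000 nM, with an expected range from 1500 nM to 15000 nM.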

Compound 3, concentration for 50% growth inhibition: 990 nM
Beside the measured number, compound 3's estimate is 8.1-fold (0.91 log units) above it, outside the stated range (below it).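

In this assay propanoyl in place of hydrogen gives an at least 10-fold lower number from compound 2 to compound 3 (1.00 log units; beyond the scatter) and propanoyl in place of methyl gives an at least 10-fold lower number from compound 1 to compound 3 (1.00 log units; beyond the scatter) on the same nitrogen. Of the three groups shown on this nitrogen, only propanoyl yields a measured number rather than a limit, while the step between methyl and hydrogen cannot be read. Going by these compounds, the true size of both steps stays open because compounds 1 and 2 rest on a limit: the limit of > 10000 nM in this assay, at which 2 of the 3 values shown sit. On these data alone, whether an acetyl group, a butanoyl chain or a cyclopropanecarbonyl group on this nitrogen would match propanoyl also remains open.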